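The source may hold more compounds than are shown below. What is called first, only, known or untested is meant among the compounds shown, and "the series" means these compounds.

The series was examined in a functional assay on MCF7 cells (Homo sapiens) for cytotoxicity, with a stated time of 72 h; a lower number here means a stronger inhibitor, a higher number a weaker inhibitor. Compound 2, `C[C@H](NC(=O)c1ccc(Cl)cc1O)C(=O)Nc1ccc(Cl)c(Cl)c1`, is the smallest member shown. In this assay compound 2 reaches only a limit of the assay, > 12500 nM, and not a number. Compound 1, `CC(C)[C@H](NC(=O)c1ccc(Cl)cc1O)C(=O)Nc1ccc(Cl)c(Cl)c1`, is built from the same core. In this assay compound 1 likewise reaches only a limit, > 10000 nM, rather than a measured number. The change between them is isopropyl in place of methyl on a saturated chain carbon bound to an amide-type nitrogen and a carbonyl carbon. The resulting step, a step that the two limits leave unreadable from compound 2 to compound 1, cannot be read in size, because the limit of > 12500 nM in this assay, at which 1 of the 3 values shown sits, and the limit of > 10000 nM in this assay, at which 2 of the 3 values shown sit, both stand at the edge of what the assay reports.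

Compound 3, `C[C@H](NC(=O)c1cc(Cl)ccc1O)C(=O)Nc1cccc(Cl)c1`, carries a different core; how the two cores differ is not broken down here. In this assay compound 3 also stands only at a limit, > 10000 nM, and no number is given for it.

Compound 4, `CC(C)[C@H](NC(=O)c1cc(Cl)ccc1O)C(=O)Nc1cccc(Cl)c1`, has not yet been measured in this assay. It differs from compound 3 by isopropyl in place of methyl on a saturated chain carbon bound to an amide-type nitrogen and a carbonyl carbon, the same change already made from compound 2 to compound 1, at the same place. Since that earlier step could not be read, and since compound 3 itself sits at > 10000 nM, the expectation for compound 4 rests only on the three limits shown. The step that the limit leaves unreadable from compound 3 to compound 4 is therefore expected to be small or unreadable, and compound 4 is estimated to give 20000 nM, within a range from 7000 nM to 60000 nM, most probably reported as a limit once more.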

Compound 4, half-maximal inhibitory concentration: > 10000 nM
Compound 4 ended at the assay's limit; the forecaster's own chance of this, stated with the estimate: 85%; the middle value does not contradict the limit.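

In this assay compound 4 gives > 10000 nM, which is a limit of the assay and not a number. The step from compound 3 to compound 4 cannot be read, because both compounds stand at the same edge of what the assay reports: the limit of > 10000 nM in this assay, at which 3 of the 4 values shown sit.

The compounds shown leave open how strongly, if at all, compound 1, compound 2, compound 3 or compound 4 acts in this assay, and whether isopropyl in place of methyl changes that.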